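A few compounds are considered here, and "the series" means these few. Any claim that something is new, unique, unknown or untested is made for them only; others in the source may bear on it.

Of the compounds shown here, two have numbers so far in a functional assay on MKN-45 cells (Homo sapiens) for inhibition, with a stated time of 72 h; a higher number here means a weaker inhibitor, a lower number a stronger inhibitor. Compound 1 (`COc1cc(C(=O)n2ccc3ccccc32)cc(OC)c1OC`) gives 5200 nM. Compound 2 (`COc1cc(C(=O)c2ccc3c(ccn3C(C)C)c2)cc(OC)c1OC`) gives 470 nM, the lower of the two numbers. The gap between them lies beyond the usual scatter, so compound 2 is the stronger inhibitor of this pair.

Compound 3 (`COc1cc(C(=O)c2ccc3c(ccn3CCN(C)C)c2)cc(OC)c1OC`) has not yet been measured. It keeps the core of compound 2 and changes one group: 2-(dimethylamino)ethyl in place of isopropyl on an aromatic nitrogen. Counted atom by atom, the change reads (2-(dimethylamino)ethyl in place of isopropyl on an aromatic nitrogen).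

Going by the values given here, no measured pair shows what a swap at this nitrogen does, so the forecast is uncertain and its range is wide. A small move towards a higher number, meaning a slightly weaker inhibitor, is expected, and it may not clearly exceed the scatter. The estimated step is a 1.7-fold higher number from compound 2 to compound 3 (0.23 log units; within the scatter). In this assay the estimate for compound 3 is 800 nM, with an expected range from 200 nM to 3500 nM.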

Compound 3, half-maximal inhibitory concentration: 2900 nM
Compound 3: the middle estimate sits 3.6-fold (0.56 log units) below what was measured; the range from low to high includes it.
By their numbers in this assay, from the lowest: compound 2; then compounds 3 and 1 (each within the scatter of the next).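

In this assay, going by these compounds alone, this is the first change at the aromatic nitrogen that can be read on its own: placing 2-(dimethylamino)ethyl there instead of isopropyl gives a 6.2-fold higher number from compound 2 to compound 3 (0.79 log units; beyond the scatter). The shared core stays the same in this pair, so the weaker inhibition of compound 3 goes with the group on this nitrogen, showing that the number at this position depends on which group it carries. No measurement among these compounds says why the number rises.

The entering group differs from isopropyl in two ways at once, with more heavy atoms and with a nitrogen that counts as a hydrogen-bond acceptor, so the compounds shown do not separate the two. On these data alone, it stays open whether an all-carbon chain such as n-pentyl, or a group such as 2-methoxyethyl, on this nitrogen would give a number closer to that of compound 2 or to that of compound 3.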